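A few compounds are considered here, and "the series" means these few. Any claim that something is new, unique, unknown or untested is made for them only; others in the source may bear on it.

Measured in a functional assay on MCF7 cells (Homo sapiens) for antiproliferative activity, read by sulforhodamine B assay, with a stated time of 48 h; on this read-out lower numbers stand for stronger inhibition and higher numbers for weaker inhibition:
Compound 1 `CCCCc1ccc(NS(=O)(=O)c2ccc(N3CCNC3=O)cc2)cc1`: 770 nM.
Compound 2 `CC(C)(C)c1ccc(NS(=O)(=O)c2ccc(N3CCNC3=O)cc2)cc1`: > 1000 nM, a limit.
Compound 3 `COc1ccc(NS(=O)(=O)c2ccc(N3CCNC3=O)cc2)cc1`: > 1000 nM, a limit.
Not yet measured: compound 4 `CC(C)Cc1ccc(NS(=O)(=O)c2ccc(N3CCNC3=O)cc2)cc1`.

Compound 3 stands at the limit of > 1000 nM in this assay, at which 2 of the 3 values shown sit. It therefore has no number, only a limit, and any step starting from it can be read only loosely.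

The change to compound 4 is isobutyl in place of methoxy on an aromatic carbon, para to a large group: isobutyl in place of methoxy on an aromatic carbon.

The closest measured comparison is an at least 1.2-fold higher number from compound 1 to compound 3 (0.11 log units; that floor lies within the scatter), which links butyl and methoxy at the same place. The related comparison an at least 1.2-fold higher number from compound 1 to compound 2 (0.11 log units; that floor lies within the scatter) links butyl and tert-butyl. Each gives only a floor, and neither floor goes beyond the scatter. The third comparison, a step that the two limits leave unreadable from compound 2 to compound 3, cannot be read at all. Isobutyl is an isomer of both butyl and tert-butyl, so compound 1 and compound 2 are the nearest guides.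

In this assay, a small step toward a lower number is expected, possibly none beyond the scatter, and another limit is quite possible. The expected step is an at least 1.1-fold lower number from compound 3 to compound 4 (0.04 log units; that floor lies within the scatter). For compound 4 the estimated value is 900 nM, with an expected range from 400 nM to 2000 nM.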

Compound 4, half-maximal inhibitory concentration: > 1000 nM
Compound 4: only a limit was reported (the forecaster's own chance of this, stated with the estimate: 50%); middle value at least 1.1-fold (0.04 log units) away from the limit.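

In this assay, isobutyl at this place, para to a large group, joins methoxy and tert-butyl in giving only a limit, which leaves compound 1, with its butyl group, as the only compound shown with a number. Among the compounds shown here, the one readable step, an at least 1.2-fold higher number from compound 1 to compound 4 (0.11 log units; that floor lies within the scatter), gives only a floor, so moving from the straight butyl chain to its isobutyl isomer shows no change that can be placed beyond the scatter. The steps among compound 2, compound 3 and compound 4 cannot be read, and the new result adds one more compound to the same ceiling: the limit of > 1000 nM in this assay, at which 3 of the 4 values shown sit.

As far as these compounds go, how far compound 2, compound 3 and compound 4 actually lie from compound 1 remains open, as their true values cannot be ordered from limits. Also open, from the compounds shown here alone, is whether a longer chain such as hexyl, or an amine at this same place, would give a number clearly separated from that of compound 1.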